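Trading a Substituted Phenyl Ring for Thiophene

The compounds below may be only part of what the source reports. "The series", "measured", "known", "first", "only" and "open" are said of these compounds alone.

Compound 1 `Cc1ccc(C2=NN(C(=S)Nc3ccccc3)C(c3ccc4c(c3)OCCO4)C2)cc1` in a functional assay on HT-29 cells (Homo sapiens) for antiproliferative activity, read by MTT assay, with a stated time of 48 h; a higher number here means a weaker inhibitor of growth, a lower number a stronger inhibitor of growth: 19500 nM
Compound 2 `CSc1ccc(C2=NN(C(=S)Nc3ccccc3)C(c3ccc4c(c3)OCCO4)C2)cc1`: > 200000 nM, a limit of the assay rather than a number
Compound 3 `COc1cccc(C2=NN(C(=S)Nc3ccccc3)C(c3ccc4c(c3)OCCO4)C2)c1`: 2920 nM

Compound 2 stands at the edge of what the assay reports, where (the limit of > 200000 nM in this assay, at which 1 of the 3 values shown sits). Compound 4 `S=C(Nc1ccccc1)N1N=C(c2cccs2)CC1c1ccc2c(c1)OCCO2` differs from it in one place: thiophen-2-yl in place of 4-(methylsulfanyl)phenyl on a carbon with a double bond to nitrogen. Among the compounds with values here, two measured steps touch the same position. an at least 68-fold lower number from compound 2 to compound 3 (1.83 log units; beyond the scatter), and an at least 10-fold higher number from compound 1 to compound 2 (1.01 log units; beyond the scatter). Both show that replacing 4-(methylsulfanyl)phenyl on that carbon has so far given a lower number. Because an at least 68-fold lower number from compound 2 to compound 3 (1.83 log units; beyond the scatter) and an at least 10-fold higher number from compound 1 to compound 2 (1.01 log units; beyond the scatter) point the same way, compound 4 is expected to return a measurable number, an at least 13-fold lower number from compound 2 to compound 4 (1.12 log units; beyond the scatter). Compound 4 is estimated at 15000 nM, with a range from 3000 nM to 150000 nM.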

Compound 4, concentration for 50% growth inhibition: 188000 nM
The estimate for compound 4 lay 13-fold (1.10 log units) below the measured number; the measured number lies above the stated range.
By their numbers in this assay, from the lowest: compound 3; then compound 1; then compound 4. At a limit, above all of these: compound 2.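

Thiophen-2-yl on this carbon weakens growth inhibition compared with both phenyl compounds that have a readable value, with a 64-fold higher number from compound 3 to compound 4 (1.81 log units; beyond the scatter) and a 9.6-fold higher number from compound 1 to compound 4 (0.98 log units; beyond the scatter), and the remaining step, an at least 1.0-fold lower number from compound 2 to compound 4 (0.02 log units; that floor lies within the scatter), rests on a limit. Compound 2 is held only by a limit of the assay, > 200000 nM, so that step shows no change that can be read. Replacing 4-(methylsulfanyl)phenyl therefore does not by itself bring the strength of compound 3, and the choice of the entering group matters. On these data alone, how a pyridin-2-yl or a 3-aminophenyl group would behave on this carbon remains open.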